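This account rests on a few compounds, and the source may have more. Where it says the series, first, only, none or still open, it means among the compounds named here.

Three compounds share one core and differ only in the aromatic group attached to an amide-type nitrogen. Compound 1 `Cc1cccc(NC(=O)COc2ccc(/C=C3\SC(=O)NC3=O)cc2)n1` carries a 6-methylpyridin-2-yl group, and in a functional assay on PC-3 cells (Homo sapiens) for inhibition (on this read-out lower numbers stand for stronger inhibition of growth and higher numbers for weaker inhibition of growth), compound 1 gives 58300 nM. Compound 2 `O=C(COc1ccc(/C=C2\SC(=O)NC2=O)cc1)Nc1ccc(F)cc1` carries a 4-fluorophenyl group. In this assay compound 2 reaches only the limit of the assay, > 100000 nM. Compound 3 `Cc1cc(Br)ccc1NC(=O)COc1ccc(/C=C2\SC(=O)NC2=O)cc1` carries a 4-bromo-2-methylphenyl group. In this assay compound 3 likewise reaches only the limit, > 100000 nM, so its standing among the three is known as a limit and not as a number. Compound 2 and compound 3 thus sit together at the limit of > 100000 nM in this assay, at which 2 of the 3 values shown sit. The step of an at least 1.7-fold higher number from compound 1 to compound 3 (0.23 log units; that floor lies within the scatter) can be read only as a floor, and the step that the two limits leave unreadable from compound 2 to compound 3 cannot be read at all.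

Compound 4 `Cc1ccc(NC(=O)COc2ccc(/C=C3\SC(=O)NC3=O)cc2)cc1Cl` differs from compound 3 in one place: 3-chloro-4-methylphenyl in place of 4-bromo-2-methylphenyl on an amide-type nitrogen. The two earlier exchanges on this nitrogen gave either a floor that lies within the scatter or an unreadable step, so no step beyond the scatter is expected from this exchange either. Compound 4 is therefore estimated at 100000 nM, with a range from 40000 nM to 300000 nM, and most likely again only a limit will be reported. The expected step of a number no higher from compound 3 to compound 4 (the limit leaves the size open) is essentially none.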

Compound 4, concentration for 50% growth inhibition: > 100000 nM
Compound 4 ended at the assay's limit; the forecaster's own chance of this, stated with the estimate: 70%; the middle value sits exactly at the limit.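

In this assay compound 4 gives > 100000 nM, which is a limit of the assay and not a number, so a third substituted phenyl group on this amide-type nitrogen ends up in the same place as the other two: the limit of > 100000 nM in this assay, at which 3 of the 4 values shown sit. Within the data shown here, measured against the only real number in the set, the result is again just a floor, an at least 1.7-fold higher number from compound 1 to compound 4 (0.23 log units; that floor lies within the scatter), so even now the 6-methylpyridin-2-yl group of compound 1 cannot be said to stand apart from the phenyl groups beyond the scatter. The steps from compound 2 and from compound 3 to compound 4 cannot be read, as both ends of each are limits.

The compounds shown leave open whether a phenyl group carrying an amine or a carboxylic acid on this nitrogen would give a real number in this assay instead of a limit. On these data alone, they also give no order among compound 2, compound 3 and compound 4, so how these three groups compare with one another remains unknown.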